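Swapping the aryl ring of a dienone for pyridine

A few compounds are considered here, and "the series" means these few. Any claim that something is new, unique, unknown or untested is made for them only; others in the source may bear on it.

Measured so far:
compound 1, `CC1=C(/C=C/C(=O)/C=C/c2ccc(C#N)cc2)C(C)(C)CCC1`, 22200 nM in a functional assay on HeLa cells (Homo sapiens) for cytotoxicity, read by sulforhodamine B assay, with a stated time of 48 h; a higher number here means a weaker inhibitor, a lower number a stronger inhibitor
compound 2, `COc1ccc(/C=C/C(=O)/C=C/C2=C(C)CCCC2(C)C)cc1`, 15700 nM in this assay
compound 3, `CC1=C(/C=C/C(=O)/C=C/c2ccc(C)cc2)C(C)(C)CCC1`, 20400 nM in this assay

Compound 3 gives the second highest number of the three, but its neighbours lie close on both sides: a 1.1-fold lower number from compound 1 to compound 3 (0.04 log units; within the scatter) and a 1.3-fold higher number from compound 2 to compound 3 (0.11 log units; within the scatter) are both within the scatter, as is a 1.4-fold lower number from compound 1 to compound 2 (0.15 log units; within the scatter). The three measured compounds therefore cannot be told apart in this assay; the group on the aromatic carbon has been exchanged three ways without a step beyond the scatter.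

Compound 4, `CC1=C(/C=C/C(=O)/C=C/c2cccnc2)C(C)(C)CCC1`, is not yet measured. It differs from compound 3 by pyridin-3-yl in place of 4-methylphenyl on a double-bonded chain carbon bound to a double-bonded chain carbon. Within the data shown here, none of the measured steps exchanges the whole ring, so no step bears on this change directly. The nearest evidence is that every change on that ring so far stayed within the scatter, which suggests a step of no more than the scatter is expected in this assay for compound 4, that is a 1.0-fold lower number from compound 3 to compound 4 (0.01 log units; within the scatter).

Compound 4 is expected to give about 20000 nM, within a range from 8000 nM to 50000 nM.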

Compound 4, half-maximal inhibitory concentration: 17400 nM
Beside the measured number, compound 4's estimate is 1.1-fold (0.06 log units) above it, within the range that was stated.
By their numbers in this assay, from the lowest: compounds 2, 4, 3 and 1 (each within the scatter of the next).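

Until now, only the group carried on the aromatic ring had changed. Compound 4 exchanges the whole ring, and in this assay the step remains small (a 1.2-fold lower number from compound 3 to compound 4 (0.07 log units; within the scatter)). On a double-bonded chain carbon bound to a double-bonded chain carbon, pyridin-3-yl, with its ring nitrogen, can therefore take the place of 4-methylphenyl without a step beyond the scatter. Nothing available explains why this exchange has so little effect on the number.

Every compound shown keeps a six-membered aromatic ring at this place, so it remains open whether pyridin-2-yl or pyridin-4-yl would behave in the same way. Also open, from the compounds shown here alone, is what a pyridine ring carrying an amine or a carboxylic acid, or a saturated ring such as piperidine, would do in this assay.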